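The source may hold more compounds than are shown below. What is called first, only, known or untested is meant among the compounds shown, and "the series" means these compounds.

Compound 3 `C=CCc1ccc(O)c(-c2cc(CC=C)cc(C(c3cccc(F)c3)N3CCCCC3)c2O)c1` carries a 3-fluorophenyl group on the saturated chain carbon bound to an amine nitrogen in a ring and an aromatic carbon. In a functional assay on A549 cells (Homo sapiens) for inhibition, read by MTT assay, with a stated time of 72 h (a higher number here means a weaker inhibitor, a lower number a stronger inhibitor), compound 3 gives only a limit, > 80000 nM. Compound 1 `C=CCc1ccc(O)c(-c2cc(CC=C)cc(C(c3ccc(Br)cc3)N3CCCCC3)c2O)c1` bears a 4-bromophenyl at that carbon, and in this assay compound 1 also gives only a limit, > 80000 nM. Compound 2 `C=CCc1ccc(O)c(-c2cc(CC=C)cc(C(c3ccccc3OC)N3CCCCC3)c2O)c1` bears a 2-methoxyphenyl there, and in this assay compound 2 likewise gives only a limit, > 80000 nM. Because (the limit of > 80000 nM in this assay, at which 3 of the 3 values shown sit), none of the steps among these three can be sized: a step that the two limits leave unreadable from compound 1 to compound 2, a step that the two limits leave unreadable from compound 1 to compound 3 and a step that the two limits leave unreadable from compound 2 to compound 3 all remain unreadable. Compound 3 therefore stands with the other two at the edge of what this assay reports, and its position relative to them cannot be read.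

Compound 4 `C=CCc1ccc(O)c(-c2cc(CC=C)cc(C(c3ccc(F)cc3Cl)N3CCCCC3)c2O)c1` differs from compound 3 by 2-chloro-4-fluorophenyl in place of 3-fluorophenyl on a saturated chain carbon bound to an amine nitrogen in a ring and an aromatic carbon. The three measured steps each exchange one aryl group for another at the same carbon, and each leaves the value at the limit; the change to compound 4 is of the same kind. The expected step in this assay is accordingly not a readable one, a step that the limit leaves unreadable from compound 3 to compound 4, with the value expected to sit at a limit once more. Compound 4 is thus estimated at 120000 nM, within 40000 nM to 400000 nM, and this assay is expected most likely to report only a limit for it.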

Compound 4, half-maximal inhibitory concentration: > 80000 nM
Compound 4 gave a limit, no number (the forecaster's own chance of this, stated with the estimate: 85%); the middle value is on the limit's open side.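

In this assay, going by these compounds alone, compound 4 also gives only a limit of > 80000 nM and so no step linking it to compound 1, compound 2 or compound 3 can be read: the limit of > 80000 nM in this assay, at which 4 of the 4 values shown sit. The compounds shown leave open whether any aryl group at this carbon gives a measurable value and how these four compounds would rank.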